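Methoxymethyl on the aryl ring of a carbamate-cored acid

The compounds below may be only part of what the source reports. "The series", "measured", "known", "first", "only" and "open" are said of these compounds alone.

Measured compounds:
compound 1, `O=C(O)CCCSCCN1C(=O)OC[C@@H]1/C=C/[C@@H](O)Cc1ccccc1`: > 10000 nM
compound 2, `Cc1cccc(C[C@H](O)/C=C/[C@H]2CCC(=S)N2CCSCCCC(=O)O)c1`: 1700 nM

Compound 1, `O=C(O)CCCSCCN1C(=O)OC[C@@H]1/C=C/[C@@H](O)Cc1ccccc1`, was tested in an assay on CHO cells for displacement of a labelled ligand from prostaglandin E2 receptor EP2 subtype (Mus musculus), read by scintillation counting, with a stated time of 60 min (a higher number here means a weaker inhibitor, a lower number a stronger inhibitor), and gave only a limit of the assay, > 10000 nM, so its true inhibition constant is not known, only that it lies at or past that limit (the limit of > 10000 nM in this assay, at which 1 of the 2 values shown sits). Compound 2, `Cc1cccc(C[C@H](O)/C=C/[C@H]2CCC(=S)N2CCSCCCC(=O)O)c1`, which carries a different core and a methyl on its aromatic ring, gives 1700 nM in this assay, a measured number rather than a limit.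

Compound 3, `COCc1cccc(C[C@H](O)/C=C/[C@H]2COC(=O)N2CCSCCCC(=O)O)c1`, is compound 1 with one change: methoxymethyl in place of hydrogen on an aromatic carbon. Nothing among the two measured compounds shows this change by itself, since compound 2 differs from compound 1 in more than one place. For the measured compounds named here, because compound 1 sits at the limit, any step for compound 3 can only be read downward or as no step at all. The step from compound 1 to compound 3 is expected to be an at least 2.5-fold lower number from compound 1 to compound 3 (0.39 log units; beyond the scatter), a drop that may or may not go beyond the scatter. Compound 3 is therefore estimated at 4000 nM, with a range from 800 nM to 20000 nM, and a fair chance that this assay again reports only a limit.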

Compound 3, inhibition constant: > 10000 nM
Compound 3 ended at the assay's limit; the forecaster's own chance of this, stated with the estimate: 45%; at least 2.5-fold (0.39 log units) between middle value and limit.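

Compound 3, like compound 1, gives only a limit in this assay, so no step can be read between compound 1 and compound 3: the limit of > 10000 nM in this assay, at which 2 of the 3 values shown sit.

The compounds shown leave open whether methoxymethyl in place of hydrogen on an aromatic carbon changes the inhibition constant at all, and in which direction.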